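The source may hold more compounds than are shown below. What is called first, only, known or untested is meant among the compounds shown, and "the series" means these compounds.

Compound 1 `Cc1ccc(Cn2c(=O)[nH]c3c(N)nc(C(F)(F)F)cc32)cn1` was tested in an in vitro ADME assay on microsomes from liver (Rattus norvegicus) for metabolic stability; a lower number here means slower removal, a higher number faster removal of the compound. For compound 1 the result is < 8.5 mL.min-1.g-1, which is a limit of the assay rather than a number (the limit of < 8.5 mL.min-1.g-1 in this assay, at which 1 of the 3 values shown sits). Compound 2 `Cc1nc(Cn2c(=O)[nH]c3c(N)nc(C(F)(F)F)cc32)cs1` carries 2-methyl-1,3-thiazol-4-yl in place of 6-methylpyridin-3-yl on a saturated chain carbon bound to an aromatic nitrogen. In this assay compound 2 also returns a limit, < 10 mL.min-1.g-1 (the limit of < 10 mL.min-1.g-1 in this assay, at which 1 of the 3 values shown sits). Hence a step that the two limits leave unreadable from compound 1 to compound 2. Compound 3 `CN1CCN(c2ccc(Cn3c(=O)[nH]c4c(N)nc(C(F)(F)F)cc43)cn2)CC1` has 4-methylpiperazin-1-yl in place of methyl on an aromatic carbon, and in this assay compound 3 gives 46 mL.min-1.g-1. That is an at least 5.4-fold higher number from compound 1 to compound 3 (0.73 log units; beyond the scatter). Compound 4 `Nc1ccc(Cn2c(=O)[nH]c3c(N)nc(C(F)(F)F)cc32)cn1`, not yet measured, differs from compound 1 by amino in place of methyl on an aromatic carbon. The change sits on an aromatic carbon, as did the step to compound 3, yet the entering group is amino rather than a ring-bearing group. For the measured compounds named here, only the step to compound 3 bears on it, and it points upward, while the unreadable step to compound 2 gives no guidance. Compound 4 is expected to stay near the low end, with a step that the limit leaves unreadable from compound 1 to compound 4 as a small step. Compound 4 is estimated at 8 mL.min-1.g-1, between 4 mL.min-1.g-1 and 20 mL.min-1.g-1.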

Compound 4, intrinsic clearance in microsomes in the Rattus norvegicus assay: < 10 mL.min-1.g-1
Compound 4: no number, only a limit; the forecaster's own chance of this, stated with the estimate: 60%; the middle value does not contradict the limit.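

In the Rattus norvegicus assay compound 4 returns < 10 mL.min-1.g-1, which is a limit of the assay and not a number. Against 4-methylpiperazin-1-yl on the same aromatic carbon, the amino group gives an at least 4.6-fold lower number from compound 3 to compound 4 (0.66 log units; beyond the scatter), while the steps linking compound 4 with compound 1 and with compound 2 cannot be read. The change from methyl to amino does register in a physicochemical assay for lipophilicity, measured as octanol-water partition, at pH 7.4 (a higher number here means a more lipophilic compound, a lower number a more polar compound), where compound 1 gives 2.3 and compound 4 gives 1.5, and the amino compound is the more polar one: the measured distribution coefficient of compound 1, 2.3, and of compound 4, 1.5, a number 0.80 log units lower (beyond the scatter)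

On these data alone, compound 1 and compound 4 carry only limits in the Rattus norvegicus assay, so whether the lower number in the physicochemical assay goes with any real difference in removal stays open. Also open, as far as these compounds go, is whether, in the Rattus norvegicus assay, a dimethylamino group or an unsubstituted piperazin-1-yl on this carbon would move towards compound 3 at 46 mL.min-1.g-1.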